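Methyl-for-hydrogen steps on a tetracyclic ketone-ester series

A few compounds are considered here, and "the series" means these few. Any claim that something is new, unique, unknown or untested is made for them only; others in the source may bear on it.

Measured so far:
compound 1, `CCO[C@@]1(CC)CCC2(CO1)[C@@H]1CCC3=C4[C@@H](CC3=O)[C@H](C(=O)OC)C[C@@]42CN(C)C1`, > 40000 nM
compound 2, `CC[C@]1(OC)CCC2(CO1)[C@@H]1CCC3=C4[C@@H](CC3=O)[C@H](C(=O)OC)C[C@@]42CN(C)C1`, > 40000 nM
compound 3, `CCC1=CCC2(CO1)[C@@H]1CCC3=C4[C@H](CC3=O)[C@H](C(=O)OC)C[C@@]42CN(C)C1`, > 40000 nM

All three values in a functional assay on MCF7 cells (Homo sapiens) for cytotoxicity, read by MTT assay, with a stated time of 48 h (on this read-out higher numbers stand for weaker inhibition and lower numbers for stronger inhibition), are limits of the assay, not numbers. Compound 1 sits at the limit > 40000 nM. Compound 2 likewise reaches only the limit > 40000 nM. Compound 3 also gives no number, only the limit > 40000 nM. The change methyl in place of hydrogen on a saturated chain carbon bound to an oxygen on a saturated carbon therefore gives the step that the two limits leave unreadable from compound 2 to compound 1, unreadable because of the limit of > 40000 nM in this assay, at which 3 of the 3 values shown sit.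

Compound 4, `COC(=O)[C@@H]1C[C@@]23CN(C)C[C@@H](CCC4=C2[C@@H]1CC4=O)C31CC=C(C(C)C)OC1`, is not yet measured. It differs from compound 3 by methyl in place of hydrogen on a saturated chain carbon bound to a double-bonded ring carbon and a saturated chain carbon. This is the same kind of change as that from compound 2 to compound 1, but the surroundings differ: in the earlier pair the carbon that takes the methyl is bound to an oxygen on a saturated carbon, whereas in compound 3 it is bound to a double-bonded ring carbon and a saturated chain carbon. How the core of compound 3 differs from the core of compound 2 is not broken down here.

With three limits and no readable step, the only expectation that rests on the data is that compound 4 behaves like compound 3. The step that the limit leaves unreadable from compound 3 to compound 4 is expected to be negligible, since compound 3 itself gives only the limit > 40000 nM. Compound 4 is estimated at 45000 nM in this assay, with a range from 15000 nM to 150000 nM, and most likely it will again be reported only as a limit.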

Compound 4, half-maximal inhibitory concentration: > 40000 nM
Compound 4 ended at the assay's limit (the forecaster's own chance of this, stated with the estimate: 85%); the middle value is on the limit's open side.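

In this assay compound 4 gives > 40000 nM, a limit of the assay and not a number. The step between compound 3 and compound 4 therefore cannot be read, because the result again rests on a limit: the limit of > 40000 nM in this assay, at which 4 of the 4 values shown sit. The compounds shown leave open how large either methyl step is and whether any compound of this series gives a number in this assay.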